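A few compounds are considered here, and "the series" means these few. Any claim that something is new, unique, unknown or untested is made for them only; others in the source may bear on it.

Measured compounds:
- compound 1 `COc1cc2nc(NCc3ccccc3)nc(NC3CCCCCC3)c2cc1OC` — in an in vitro functional assay on B300-19 cells for antagonist activity at C-C chemokine receptor type 4 (Homo sapiens), read by GTPgammaS binding, tested at 1 uM (a higher number here means more inhibition at the concentration tested (going by the name of the read-out), a lower number less inhibition), compound 1 gives 13%
- compound 2 `COc1cc2nc(N3CCC(N4CCCC4)CC3)nc(N3CCCCC3)c2cc1OC` — in this assay compound 2 gives 8%

Where compound 1 stands is soon told: only two numbers exist, and the gap between compound 1 and compound 2 lies within the usual scatter of repeated measurements, so neither can be told apart from the other on the basis of this assay alone. Both show weak inhibition at the concentration tested.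

The next compound, compound 3 `COc1cc2nc(NCc3cccs3)nc(NC3CCCCCC3)c2cc1OC`, departs from compound 1 in a single place: thiophen-2-yl in place of phenyl on a saturated chain carbon bound to a nitrogen on an aromatic ring. Within the data shown here, nothing among the measured pairs speaks to this kind of exchange, since compound 1 and compound 2 differ in several places at once and no step between them is defined. The expectation therefore rests on the low level of compound 1 itself, with 13% as the anchor, and on the small size of the change. The step of a number 1 percentage points lower from compound 1 to compound 3 (within the scatter) is expected to be none beyond the scatter. Compound 3 is thus estimated at 12% in this assay, with a range from -5% to 30%.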

Compound 3, a percentage reported as inhibition, at one concentration (the size of the read-out at that concentration, not a potency): 0%
Beside the measured number, compound 3's estimate is 12 percentage points above it, and the stated range covers the measured number.
By their numbers in this assay, from the lowest: compounds 3, 2 and 1 (each within the scatter of the next, the first and the last beyond it).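

Among these compounds, the exchange of phenyl for thiophen-2-yl on a saturated chain carbon bound to a nitrogen on an aromatic ring comes with a number 13 percentage points lower from compound 1 to compound 3 (beyond the scatter) in this assay, and this is the only step so far that can be read at one place on the shared core. It shows that this position is not indifferent to the exchange, even at a level of inhibition this low: with everything else kept as in compound 1, the swap of one aromatic ring for the other leaves compound 3 at 0%, so the small signal of compound 1 does not carry over. Nothing measured here accounts for the step, which stands as a single observation on one pair.

The compounds shown leave open whether a pyridin-2-yl ring, a 2-phenylethyl chain or a simple cyclohexylmethyl group at this place would keep, raise or lose the inhibition seen with benzyl. They also leave open whether the same exchange would give a step of similar size on a compound with much stronger inhibition in this assay, since both members of this pair sit near the bottom of the read-out.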